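Adding a pyrrolidinyl ring to a dihydroquinolinone cytotoxic agent

The compounds below may be only part of what the source reports. "The series", "measured", "known", "first", "only" and "open" are said of these compounds alone.

Measured so far:
compound 1 `O=C1CC(c2ccccc2)Nc2ccccc21` gives 0.013 ug/mL
compound 2 `COc1cccc(C2CC(=O)c3ccccc3N2)c1` gives 0.32 ug/mL

Both numbers come from a functional assay on CAKI-1 cells (Homo sapiens) for cytotoxicity, read by sulforhodamine B assay; on this read-out higher numbers stand for an effect only at larger amounts of compound and lower numbers for an effect already at smaller amounts. Compound 2 holds the highest of the two numbers; its nearest neighbour is compound 1, and the step of a 25-fold higher number from compound 1 to compound 2 (1.39 log units; beyond the scatter) shows how far apart they lie.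

Compound 3 `COc1cccc(C2CC(=O)c3cc(N4CCCC4)ccc3N2)c1` has not yet been measured in this assay. It differs from compound 2 in one place: pyrrolidin-1-yl in place of hydrogen on an aromatic carbon. For the measured compounds named here, the only measured step, from compound 1 to compound 2, concerns a methoxy group on a different aromatic carbon and says nothing about a pyrrolidin-1-yl group entering on the fused ring. No measured comparison bears on this change, so the expectation is for no step beyond the scatter, with a wide margin of doubt on either side. The estimate for compound 3 in this assay is therefore 0.3 ug/mL, within 0.05 ug/mL to 2 ug/mL, which means an expected step of a 1.1-fold lower number from compound 2 to compound 3 (0.03 log units; within the scatter).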

Compound 3, concentration for half-maximal effect: 0.008 ug/mL
Compound 3: middle estimate off by 38-fold (1.57 log units), on the high side, and the stated range ends above it.
By their numbers in this assay, from the lowest: compounds 3 and 1 (each within the scatter of the next); then compound 2.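

In this assay, placing pyrrolidin-1-yl on the fused part of the molecule gives a 40-fold lower number from compound 2 to compound 3 (1.60 log units; beyond the scatter), so the cytotoxic effect now appears at much smaller amounts of compound. For the compounds shown here, the only earlier step concerned a methoxy group on a different aromatic carbon and went the other way, whereas this result shows that the hydrogen on the fused ring can be replaced with a large gain. Nothing measured here explains why this group has so strong an effect.

As far as these compounds go, it remains open whether the gain depends on the nitrogen, the ring or both, which a dimethylamino group or a piperidine ring at the same carbon could help to separate. Also open, from the compounds shown here alone, is whether pyrrolidin-1-yl would give a similar step on compound 1, which has no methoxy group.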